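A few compounds are considered here, and "the series" means these few. Any claim that something is new, unique, unknown or untested is made for them only; others in the source may bear on it.

Among the measured compounds shown here, compound 1, `COc1ccc(NC(=O)Nc2cccc(-c3nc(-c4ccc(NC(=O)c5cccnc5)cc4Cl)no3)c2)cc1C(F)(F)F`, is the only compound here with a full number in a functional assay on MDA-MB-231 cells (Homo sapiens) for antiproliferative activity, read by MTT assay, with a stated time of 72 h; a higher number here means a weaker inhibitor, a lower number a stronger inhibitor; in this assay compound 1 gives 1700 nM. Compound 2, `CC(=O)Nc1ccc(NC(=O)Nc2cccc(-c3nc(-c4ccc(NC(=O)c5cccnc5)cc4Cl)no3)c2)cc1`, returns only a limit of the assay in this assay, > 10000 nM, rather than a number. For the measured compounds named here, the one measured step, an at least 5.8-fold higher number from compound 1 to compound 2 (0.76 log units; beyond the scatter), therefore rests on (the limit of > 10000 nM in this assay, at which 1 of the 2 values shown sits).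

Compound 3, `O=C(Nc1cccc(-c2nc(-c3ccc(NC(=O)c4cccnc4)cc3Cl)no2)c1)Nc1ccc(NC(=O)C2CC2)c(C(F)(F)F)c1`, has not yet been measured. It differs from compound 1 by (cyclopropylcarbonyl)amino in place of methoxy on an aromatic carbon, so the trifluoromethyl group stays while an acylamino group of the kind carried by compound 2 enters. Going by the values given here, the step from compound 1 to compound 2 is the only guide and points toward a weaker inhibitor, but that step changed the whole aryl group, whereas compound 3 keeps the trifluoromethyl group. A modest loss is therefore expected, a 2.4-fold higher number from compound 1 to compound 3 (0.37 log units; beyond the scatter), rather than a fall to the limit. Compound 3 is estimated at 4000 nM, with a range from 1200 nM to 15000 nM.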

Compound 3, half-maximal inhibitory concentration: 200 nM
Estimate against measurement, compound 3: 20-fold (1.30 log units) above; the measured number lies below the stated range.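

In this assay, the aromatic carbon ortho to a trifluoromethyl group and para to a large group accepts a much larger substituent than methoxy, and swapping in (cyclopropylcarbonyl)amino gives an 8.5-fold lower number from compound 1 to compound 3 (0.93 log units; beyond the scatter). Among the compounds shown here, this is the first change here confined to that single position with the trifluoromethyl group kept, and it is the first to lower the number rather than raise it, so an acylamino group at this carbon is compatible with stronger inhibition of cell growth. The values shown offer nothing that accounts for this gain.

The compounds shown leave open whether the gain depends on the cyclopropyl ring or on the amide hydrogen. They also leave open how an amine or a longer acyl chain on this carbon would behave, and whether the trifluoromethyl group is needed at all.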